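Methoxy added beside the sulfonamide in a vanilloid antagonist series

This account rests on a few compounds, and the source may have more. Where it says the series, first, only, none or still open, it means among the compounds named here.

Working notes. Among the compounds with values here, compound 2 `CC(C(=O)NCC(COC(=O)C(C)(C)C)Cc1ccc(C(C)(C)C)cc1)c1ccc(NS(C)(=O)=O)cc1` gives the lowest of the two numbers measured so far in an assay on CHO cells for displacement of a labelled ligand from transient receptor potential cation channel subfamily V member 1 (Rattus norvegicus) (on this read-out higher numbers stand for weaker inhibition and lower numbers for stronger inhibition), with 55 nM; compound 1 `COc1cc(C(C)(C)C(=O)NCC(COC(=O)C(C)(C)C)Cc2ccc(C)c(C)c2)ccc1NS(C)(=O)=O` gives 153 nM in this assay, a gap beyond the usual scatter, though the two structures differ in several places at once. Compound 3 `COc1cc(C(C)C(=O)NCC(COC(=O)C(C)(C)C)Cc2ccc(C(C)(C)C)cc2)ccc1NS(C)(=O)=O` follows compound 2 with methoxy in place of hydrogen on an aromatic carbon, ortho to a methanesulfonamido group. Within the data shown here, no measured pair isolates this change. The step of a 1.4-fold lower number from compound 2 to compound 3 (0.14 log units; within the scatter) is therefore expected to be small, at most a modest gain not clearly beyond the scatter. Compound 3 is estimated at 40 nM, within 15 nM to 120 nM.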

Compound 3, inhibition constant: 24 nM
Compound 3: the middle estimate sits 1.7-fold (0.22 log units) above what was measured; measured number inside the range.
By their numbers in this assay, from the lowest: compound 3; then compound 2; then compound 1.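

In this assay, within the data shown here, methoxy in place of hydrogen on this aromatic carbon, ortho to a methanesulfonamido group, gives a 2.3-fold lower number from compound 2 to compound 3 (0.36 log units; beyond the scatter) as the first reading of this change on its own. The gain is modest but beyond the scatter, so the position accepts methoxy without loss, on this single pair. Nothing at hand accounts for the gain.

As far as these compounds go, whether ethoxy, hydroxy or a chlorine atom at this carbon would match methoxy stays open. From the compounds shown here alone, compound 1 also carries methoxy but differs from compound 3 in several places, so whether the step holds on other cores stays open too.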